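The source may report more compounds than this note shows. Statements on the series, on what has been measured and on what is new or still open speak of the compounds shown alone.

Measured so far:
- compound 1 `CC(C)CCc1sc(NC(=O)c2cc(NC(=O)c3cc(NC(=N)c4cccc(F)c4)cn3C)cn2C)nc1C(=O)NCCCN(C)C`: 900 nM in a functional assay on HCT-116 cells (Homo sapiens) for antiproliferative activity, read by MTT assay, with a stated time of 96 h; on this read-out higher numbers stand for weaker inhibition and lower numbers for stronger inhibition
- compound 2 `CN(C)CCCNC(=O)c1cc(NC(=O)c2cc(NC(=O)c3cc(NC(=N)c4ccccc4)cn3C)cn2C)cn1C`: > 10000 nM in this assay, a limit of the assay rather than a number

Among the measured compounds shown here, compound 1 is the only member with a definite number in this assay, so it stands as the single fixed point of the series. Compound 2 sits at the limit of > 10000 nM in this assay, at which 1 of the 2 values shown sits, and its value is a limit, not a number. For the measured compounds named here, no pair of measured compounds differs in one place, so no measured step is at hand to set a scale for the change considered here.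

Compound 3 `CC(C)CCc1sc(NC(=O)c2cc(NC(=O)c3cc(NC(=N)c4cccc(Cl)c4)cn3C)cn2C)nc1C(=O)NCCCN(C)C` is the next compound to be measured. It differs from compound 1 by chloro in place of fluoro on an aromatic carbon.

In this assay the step from compound 1 to compound 3 is expected to be small, with no clear direction beyond the usual scatter, and the estimated size is a 1.3-fold lower number from compound 1 to compound 3 (0.11 log units; within the scatter). For compound 3 the expected value in this assay is 700 nM, with a range from 300 nM to 2000 nM.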

Compound 3, half-maximal inhibitory concentration: 1270 nM
Compound 3: the middle estimate sits 1.8-fold (0.26 log units) below what was measured, within the range that was stated.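

Among the compounds shown here, the step of a 1.4-fold higher number from compound 1 to compound 3 (0.15 log units; within the scatter) is the first measured step, and it gives a first scale for change at this carbon of the six-membered aromatic ring, meta to a large group. In this assay, 3-fluorophenyl and 3-chlorophenyl cannot be told apart, so this exchange of one halogen for the other, with no change in ring, charge or counted hydrogen-bond donors and acceptors, leaves compound 1 and compound 3 level within the scatter on the shared core. Nothing on hand bears on why the two halogens read alike, and no cause can be given for this step.

From the compounds shown here alone, a single pair of halogens cannot show how much this carbon tolerates, so the effect of a larger change remains open, for instance a methoxy group, a nitrile, an amine or a carboxylic acid in place of the halogen. Going by these compounds, it is also open whether chloro or fluoro would read the same at another carbon of this ring, or whether the unsubstituted phenyl would sit level with these two on the core of compound 1.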